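A heteroaryl swap on a weakly active amide series

The source may report more compounds than this note shows. Statements on the series, on what has been measured and on what is new or still open speak of the compounds shown alone.

In a functional assay on LoVo cells (Homo sapiens) for inhibition, read by MTT assay, with a stated time of 72 h (on this read-out higher numbers stand for weaker inhibition and lower numbers for stronger inhibition), compound 2 `Cc1noc(C)c1-c1cnc(N)c(Oc2ccc(C(=O)NC3CCCC3)cc2)n1` gives 25200 nM. Compound 1 `Cc1noc(C)c1-c1cnc(N)c(Oc2ccc(C(=O)NC3CC3)cc2)n1` reaches only the limit of this assay, > 100000 nM, which is a limit and not a number. Compound 3 `Cc1noc(C)c1-c1cnc(N)c(Oc2ccc(C(=O)Nc3ccccc3Cl)cc2)n1` stands at the same limit, > 100000 nM, so only a bound and no number is known for it; this is the limit of > 100000 nM in this assay, at which 2 of the 3 values shown sit. The three measured steps all concern the amide-type nitrogen: an at least 3.9-fold lower number from compound 1 to compound 2 (0.59 log units; beyond the scatter), an at least 3.9-fold higher number from compound 2 to compound 3 (0.59 log units; beyond the scatter) and a step that the two limits leave unreadable from compound 1 to compound 3.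

Compound 4 `Cn1cc(-c2cnc(N)c(Oc3ccc(C(=O)Nc4ccccc4Cl)cc3)n2)cn1` differs from compound 3 at another place: 1-methyl-1H-pyrazol-4-yl in place of 3,5-dimethyl-1,2-oxazol-4-yl on an aromatic carbon. For the measured compounds named here, none of the measured steps touches that ring, so no measured step bears directly on this change, and the series gives no reading of its direction. Since compound 3 sits at the limit > 100000 nM, compound 4 is expected to remain weak, with the step of an at least 1.2-fold lower number from compound 3 to compound 4 (0.09 log units; that floor lies within the scatter) estimated to stay inside the scatter. Compound 4 is therefore estimated at 80000 nM, between 20000 nM and 300000 nM.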

Compound 4, half-maximal inhibitory concentration: 41400 nM
The estimate for compound 4 lay 1.9-fold (0.29 log units) above the measured number; the measured number falls inside the stated range.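

For the compounds shown here, until here the measured steps concerned only the group on the amide-type nitrogen, so this is the first reading of the place para to an amino group on the shared core. In this assay, 1-methyl-1H-pyrazol-4-yl in place of 3,5-dimethyl-1,2-oxazol-4-yl gives an at least 2.4-fold lower number from compound 3 to compound 4 (0.38 log units; beyond the scatter), which shows that this place can move the read-out and brings the 2-chlorophenyl amide to a measurable number. The true size of the step stays unknown, because compound 3 stands at a limit and not a number: the limit of > 100000 nM in this assay, at which 2 of the 4 values shown sit.

This single pair does not show whether the same swap would lower the number for the cyclopentyl amide of compound 2. From the compounds shown here alone, what a pyridine ring or a plain phenyl at this place would give also remains open.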